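The compounds below may be only part of what the source reports. "The series", "measured", "known", "first", "only" and "open" are said of these compounds alone.

Measured so far in a functional assay on NCI-H1581 cells (Homo sapiens) for inhibition, read by MTT assay, with a stated time of 48 h, tested at 10 uM; a higher number here means more inhibition at the concentration tested (going by the name of the read-out), a lower number less inhibition:
- compound 1, `COc1cc(NC(=O)Nc2cc(Nc3ccc(C)c(F)c3)ncn2)cc(OC)c1`: 38%
- compound 2, `COc1ccc(Nc2cc(NC(=O)Nc3c(Cl)cccc3Cl)ncn2)cc1C`: 45.1%
- compound 3, `COc1cc(NC(=O)Nc2cc(Nc3cc(Br)ccc3OC)ncn2)cc(OC)c1`: 23.1%

Compound 3 stands lowest of the three, with compound 1 nearest and compound 2 furthest above it, both gaps beyond the scatter. Within the data shown here, the only single-point step in the set, a number 14.9 percentage points lower from compound 1 to compound 3 (beyond the scatter), shows a modest loss on moving to 5-bromo-2-methoxyphenyl on the nitrogen on the aromatic ring.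

Compound 4, `COc1cc(NC(=O)Nc2cc(Nc3ccc(OC)c(C)c3)ncn2)cc(OC)c1`, is not yet measured. It differs from compound 3 as 4-methoxy-3-methylphenyl in place of 5-bromo-2-methoxyphenyl on a nitrogen on an aromatic ring. Compound 2 carries the same 4-methoxy-3-methylphenyl group but differs from compound 3 in a second place, so it gives only a rough pointer; its value sits above that of compound 3. The step from compound 1 to compound 3 bears on the change in reverse: replacing 5-bromo-2-methoxyphenyl is expected to recover ground, so a moderate rise in this assay beyond the scatter is expected, a number 14.9 percentage points higher from compound 3 to compound 4 (beyond the scatter). For compound 4 the estimate is 38%, within 24% to 54%.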

Compound 4, a percentage reported as inhibition, at one concentration (the size of the read-out at that concentration, not a potency): 19.7%
Compound 4: the middle estimate sits 18.3 percentage points above what was measured; measured number below the stated range.
By their numbers in this assay, from the lowest: compounds 4 and 3 (each within the scatter of the next); then compounds 1 and 2 (each within the scatter of the next).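

In this assay the step of a number 3.4 percentage points lower from compound 3 to compound 4 (within the scatter) shows that, with 3,5-dimethoxyphenyl on the amide-type nitrogen, these two groups on the nitrogen on the aromatic ring cannot be told apart, while the step of a number 18.3 percentage points lower from compound 1 to compound 4 (beyond the scatter) keeps 3-fluoro-4-methylphenyl as the better of the two groups compared there. Among these compounds, the step of a number 25.4 percentage points lower from compound 2 to compound 4 (beyond the scatter) gives the first reading of the amide-type nitrogen as a place where the number moves, with 4-methoxy-3-methylphenyl held constant. No measurement at hand accounts for these steps.

As far as these compounds go, whether 2,6-dichlorophenyl on the amide-type nitrogen would also raise the number with 3-fluoro-4-methylphenyl or 5-bromo-2-methoxyphenyl in place stays open. So does the effect of a basic amine such as piperazine on the ring carried by the nitrogen on the aromatic ring.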